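Trimming a Piperazine Tail: Effect on Vero Cell Tolerance

The source may hold more compounds than are shown below. What is called first, only, known or untested is meant among the compounds shown, and "the series" means these compounds.

Measured so far in an ADME assay on Vero cells (Chlorocebus sabaeus) for cytotoxicity; a higher number here means that more compound is tolerated, a lower number that less compound is tolerated:
- compound 1, `COc1ccc(-c2nc3cc(C(F)(F)F)ccc3[nH]2)c(N)c1`, gives 50000 nM.
- compound 2, `CN1CCN(CC(=O)Nc2ccc(-c3nc4cc(C(F)(F)F)ccc4n3C)cc2)CC1`, gives only a limit, > 100000 nM.
- compound 3, `COc1ccc(-c2nc3cc([N+](=O)[O-])ccc3[nH]2)c(OC)c1`, gives only a limit, > 100000 nM.

Compound 2 sits at the limit of > 100000 nM in this assay, at which 2 of the 3 values shown sit, so its true tolerance is not pinned down, only known to lie at or beyond that edge. Compound 4, `CCC(=O)Nc1ccc(-c2nc3cc(C(F)(F)F)ccc3n2C)cc1`, differs from compound 2 in one place: methyl in place of 4-methylpiperazin-1-yl on a saturated chain carbon bound to a carbonyl carbon. Within the data shown here, no measured step speaks directly to this change, and compound 1 shows that a measurable number can appear. The step from compound 2 to compound 4 in this assay is expected to be small, likely none beyond the scatter, as an at least 1.2-fold lower number from compound 2 to compound 4 (0.09 log units; that floor lies within the scatter). Compound 4 is therefore estimated at 80000 nM, with a range from 30000 nM to 150000 nM.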

Compound 4, half-maximal cytotoxic concentration: > 100000 nM
Compound 4 ended at the assay's limit; the forecaster's own chance of this, stated with the estimate: 55%; at least 1.2-fold (0.09 log units) between middle value and limit.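

Compound 2 and compound 4 both give only a limit, so no step between them can be read: the limit of > 100000 nM in this assay, at which 3 of the 4 values shown sit.

As far as these compounds go, whether methyl in place of 4-methylpiperazin-1-yl changes the outcome in this assay stays open.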